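The source may report more compounds than this note shows. Statements on the series, on what has been measured and on what is new or still open speak of the compounds shown alone.

Compound 2 `N#Cc1ccc(F)c(OC(=O)N2CCC(C(c3ccccc3)c3ccccc3)CC2)c1` was tested in an assay on isolated protein for inhibition of Fatty-acid amide hydrolase 1 (Rattus norvegicus), read by fluorescence; on this read-out higher numbers stand for weaker inhibition and lower numbers for stronger inhibition. For compound 2 the result is only a limit of the assay, > 1000 nM. Compound 1 `N#Cc1ccnc(OC(=O)N2CCC(C(c3ccccc3)c3ccccc3)CC2)c1` is the nearest comparison, and compound 1 also returns only a limit, > 1000 nM. Going by the values given here, the one step between measured compounds, a step that the two limits leave unreadable from compound 1 to compound 2, is therefore unreadable in size: the limit of > 1000 nM in this assay, at which 2 of the 2 values shown sit. Compound 3 `COc1cc(C#N)cc(OC(=O)N2CCC(C(c3ccccc3)c3ccccc3)CC2)c1` has not yet been measured; it differs from compound 2 by 3-cyano-5-methoxyphenyl in place of 5-cyano-2-fluorophenyl on an oxygen next to a carbonyl group. Among the compounds with values here, no measured step bears directly on this change, and the single known step is hidden by two limits, so its size and direction cannot be carried over. The two values known are limits, and compound 3 is accordingly expected to remain weak, the expected step being a step that the limit leaves unreadable from compound 2 to compound 3. The value for compound 3 in this assay is estimated at 3000 nM, within a range from 700 nM to 20000 nM.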

Compound 3, half-maximal inhibitory concentration: > 1000 nM
Compound 3 gave a limit, no number; the forecaster's own chance of this, stated with the estimate: 70%; the middle value is on the limit's open side.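

Compound 3 also gives only a limit of the assay, > 1000 nM. The sizes of the steps among compound 1, compound 2 and compound 3 therefore cannot be read: the limit of > 1000 nM in this assay, at which 3 of the 3 values shown sit.

Going by these compounds, whether these three groups on the oxygen differ at all in inhibition, and how strongly each compound inhibits the enzyme, remains open.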